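A few compounds are considered here, and "the series" means these few. Any claim that something is new, unique, unknown or untested is made for them only; others in the source may bear on it.

Compound 1 `CN(C)CCCNc1nc(-c2ccc(NC(=O)Nc3ccc(F)cc3)cc2)nc2c(Cl)c(Cl)sc12` serves as the reference point of this small set. Within the data shown here, in a functional assay on MKN-45 cells (Homo sapiens) for cytotoxicity, read by MTT assay, with a stated time of 72 h (a lower number here means a stronger inhibitor, a higher number a weaker inhibitor), compound 1 gives 1120 nM, the lowest number among the three compounds measured so far. Compound 2 `CN(C)CCCNc1nc(-c2ccc(NC(=O)Nc3ccc(Cl)cc3Cl)cc2)nc2c(Cl)c(Cl)sc12` gives 2560 nM in this assay, and compound 3 `Cc1ccc(NC(=O)Nc2ccc(-c3nc(NCCCN(C)C)c4sc(Cl)c(Cl)c4n3)cc2)cc1` gives 3700 nM. Both steps away from compound 1 are modest: a 2.3-fold higher number from compound 1 to compound 2 (0.36 log units; beyond the scatter) and a 3.3-fold higher number from compound 1 to compound 3 (0.52 log units; beyond the scatter); between the other two compounds, a 1.4-fold higher number from compound 2 to compound 3 (0.16 log units; within the scatter). All three of these steps alter the aryl group on the amide-type nitrogen, while the amine-bearing chain on the shared core stays unchanged throughout.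

Compound 4 `CCN(CC)CCNc1nc(-c2ccc(NC(=O)Nc3ccc(F)cc3)cc2)nc2c(Cl)c(Cl)sc12` is yet to be measured in this assay. It differs from compound 1 in that chain: diethylamino in place of (dimethylamino)methyl on a saturated chain carbon, two bonds along the chain from a nitrogen on an aromatic ring. Among the measured compounds shown here, none of the measured steps touches this part of the molecule, so the data offer nothing that calibrates the size of such a change; what is known is only that the changes made elsewhere produced modest shifts at most. A change confined to this chain is expected to give a step in this assay that is small, in either direction, and most likely none beyond the scatter: a 1.1-fold higher number from compound 1 to compound 4 (0.03 log units; within the scatter). Compound 4 is therefore estimated at 1200 nM, with a range from 450 nM to 3200 nM.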

Compound 4, half-maximal inhibitory concentration: 1370 nM
Compound 4: the middle estimate sits 1.1-fold (0.06 log units) below what was measured, within the range that was stated.
By their numbers in this assay, from the lowest: compounds 1, 4, 2 and 3 (each within the scatter of the next, the first and the last beyond it).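

Among these compounds, compound 4 is the first compound here to alter the amine-bearing chain rather than the aryl group on the amide-type nitrogen, and in this assay the change of 3-(dimethylamino)propyl to 2-(diethylamino)ethyl gives a 1.2-fold higher number from compound 1 to compound 4 (0.09 log units; within the scatter). This single step therefore shows that the chain can be rewritten in this way without a readable change in the number, whereas the aryl steps away from compound 1 to compound 2 and compound 3 both lie beyond the scatter. No measurement shown here accounts for this result.

The step alters the chain length and the substituents on the terminal nitrogen together, so the compounds shown cannot separate the two, and a 3-(diethylamino)propyl chain or a 2-(dimethylamino)ethyl chain would be needed to tell them apart. From the compounds shown here alone, it also remains open how this position would respond to a more drastic replacement, such as a morpholine or piperidine ring at the chain end, a longer chain, or a carboxylic acid in place of the amine, and whether the aryl groups keep their order on the diethylamino chain.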